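Trifluoromethyl on compound 1: expected tolerance in MDCK cells

The compounds below may be only part of what the source reports. "The series", "measured", "known", "first", "only" and "open" are said of these compounds alone.

In an ADME assay on MDCK cells (Canis lupus familiaris) for cytotoxicity, read by MTT assay, with a stated time of 72 h (a higher number here means that more compound is tolerated, a lower number that less compound is tolerated), compound 1 (`Cc1nc([N+](=O)[O-])cn1CC(=O)Nc1ccccc1`) gives 1140000 nM and compound 2 (`Cc1nc([N+](=O)[O-])cn1CC(=O)Nc1ccc(C#N)cc1`) gives 672000 nM as its value. Within the data shown here, these two values lie within the scatter of each other, which leaves compound 1 with no distinct place on the numbers so far.

Compound 3 (`Cc1nc([N+](=O)[O-])cn1CC(=O)Nc1cccc(C(F)(F)F)c1`) departs from compound 1 by a single change: trifluoromethyl in place of hydrogen on an aromatic carbon (trifluoromethyl in place of hydrogen on an aromatic carbon, meta to a large group).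

Among the measured compounds shown here, the one measured step that bears on this change, cyano in place of hydrogen on an aromatic carbon, is a 1.7-fold lower number from compound 1 to compound 2 (0.23 log units; within the scatter) and on that basis no shift beyond the scatter is expected in this assay with a lower number as the likelier direction. For the measured compounds named here, the support is thin: no measured compound carries trifluoromethyl, and a single step with a different group is the only guide.

The expected step is a 1.8-fold lower number from compound 1 to compound 3 (0.24 log units; within the scatter) on this estimate. For compound 3 the estimated value is 650000 nM within an expected range of 280000 nM to 1300000 nM in this read-out.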

Compound 3, half-maximal cytotoxic concentration: 435000 nM
Compound 3: the middle estimate sits 1.5-fold (0.17 log units) above what was measured; the measured number falls inside the stated range.
By their numbers in this assay, from the lowest: compounds 3, 2 and 1 (each within the scatter of the next, the first and the last beyond it).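

In this assay, among these compounds, trifluoromethyl in place of hydrogen on an aromatic carbon, meta to a large group, gives a 2.6-fold lower number from compound 1 to compound 3 (0.42 log units; beyond the scatter) and is the first single change to move the number beyond the scatter. Among the compounds shown here, the earlier nitrile step left compound 1 with no distinct place, whereas compound 1 now stands apart from compound 3, so substitution on this ring can lower the tolerated concentration by a modest but readable amount, though the series still shows only this one such step. No measurement at hand accounts for the step, and the data do not say what about the change produces it.

The compounds shown leave open whether the step follows trifluoromethyl itself or its place on the ring, since this group appears at one place only and no compound carries it elsewhere on the ring. They also leave open how a chlorine, a methoxy group, an amine or a carboxylic acid at the same place would compare with trifluoromethyl in this read-out.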